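The compounds below may be only part of what the source reports. "The series", "measured", "known", "first", "only" and "open" are said of these compounds alone.

Of the compounds shown here, three with closely related structures have been tested in an ADME assay on microsomes from liver (Rattus norvegicus) for metabolic stability, read by mass spectrometry, using NADPH, with a stated time of 10 min (on this read-out lower numbers stand for a less stable compound and higher numbers for a more stable compound), so far. In this test compound 1 `CCCCc1[nH]c(=O)c(-c2n[nH]c(Cc3ccccc3)n2)c(O)c1-c1c(OC)cccc1OC` gives 15% and compound 2 `CCCCc1[nH]c(=O)c(-c2nnc(Cc3cccc(Cl)c3)o2)c(O)c1-c1c(OC)cccc1OC` gives 38% (the lower two numbers). Compound 3 `CCCCc1[nH]c(=O)c(-c2nnc(Cc3ccccc3)o2)c(O)c1-c1c(OC)cccc1OC` gives 53% (the highest of the three). Compound 2 lies nearest to it and compound 1 furthest from it.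

The next compound, compound 4 `CCCCc1[nH]c(=O)c(-c2nnc(Cc3ccccc3Cl)o2)c(O)c1-c1c(OC)cccc1OC`, is built from compound 3 by one small edit: chloro in place of hydrogen on an aromatic carbon. The same difference can be read as benzyl to 2-chlorobenzyl, and the new chloro sits ortho to a large group.

Going by the values given here, only one measured step bears on this edit. That step is a number 15 percentage points higher from compound 2 to compound 3 (beyond the scatter) and it takes a chloro away from the same kind of benzyl group. Read in reverse, it suggests that adding a chloro could lower the number. The chloro of compound 2 sits at a different place on the ring, however, so this single pair is only a rough guide. A fall of similar or slightly smaller size is therefore expected, with an estimated step of a number 13 percentage points lower from compound 3 to compound 4 (beyond the scatter) in this assay for this edit. For compound 4 the estimated value is 40% (expected range 23% to 58%).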

Compound 4, percent of the compound remaining: 24%
Compound 4: the middle estimate sits 16 percentage points above what was measured; measured number inside the range.
By their numbers in this assay, from the lowest: compounds 1 and 4 (each within the scatter of the next); then compound 2; then compound 3.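

In this assay, changing benzyl to 2-chlorobenzyl gives a number 29 percentage points lower from compound 3 to compound 4 (beyond the scatter), so a chloro ortho to a large group lowers the share of compound left intact, and this fall is larger than the earlier pair suggested. The place of the chloro on the ring also counts, not only its presence: exchanging 3-chlorophenyl for 2-chlorophenyl gives a number 14 percentage points lower from compound 2 to compound 4 (beyond the scatter), although both compounds carry one chloro on the same benzyl ring. No measurement is at hand that would explain either step, so the reason for these differences remains unknown.

On these data alone, whether a fluoro or methoxy group on the same aromatic carbon would give a similar fall stays open, as does whether 2-chlorobenzyl would act in the same way on the core of compound 1. The compounds shown also leave open which part of these molecules changes in the microsomes, and whether replacing the butyl chain with a shorter chain or an amine would alter the pattern seen with the chloro groups.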